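This account rests on a few compounds, and the source may have more. Where it says the series, first, only, none or still open, it means among the compounds named here.

Measured so far:
compound 1, `COc1cc(OC)c(OC)cc1/C=C/COC(=O)/C=C/c1ccccc1Cl`: 25%
compound 2, `COc1cc(OC)c(OC)cc1/C=C/COC(=O)/C=C/c1ccc(F)cc1`: 0%

In a functional assay on the whole organism (strain Kunming) with Mus musculus as the target, with a stated time of 0.5 h, at a dose of 300 mg/kg by the intraperitoneal route (a higher number here means a weaker effect of the compound at the dose given, a lower number a stronger effect), compound 2 gives 0%, the lowest of the two numbers; its nearest neighbour is compound 1, which gives 25%. Among the measured compounds shown here, the one step known, a number 25 percentage points lower from compound 1 to compound 2 (beyond the scatter), exchanged one group on the ring at the end of the double-bonded chain. It lowered the read-out by a modest amount.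

Compound 3, `COc1ccc(/C=C/C(=O)OC/C=C/c2cc(OC)c(OC)cc2OC)cc1`, is the next member of the series. It differs from compound 2 as follows: methoxy in place of fluoro on an aromatic carbon. For the measured compounds named here, no measured pair shows this exchange, so the only guidance is that the same ring has already been altered once, by the step from compound 1 to compound 2, with a modest result. A methoxy group in place of fluoro is therefore expected to shift this assay by a number 10 percentage points higher from compound 2 to compound 3 (within the scatter), a small rise that may stay within the scatter. Compound 3 is estimated at 10%, between 0% and 30%.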

Compound 3, a percentage reported as activity, at one dose (the size of the read-out at that dose, not a potency): 0%
For compound 3 the middle estimate is 10 percentage points above the measured one, within the range that was stated.
By their numbers in this assay, from the lowest: compounds 2 and 3 (each within the scatter of the next); then compound 1.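

In this assay, the exchange of 4-fluorophenyl for 4-methoxyphenyl gives no change at the digits printed from compound 2 to compound 3 (within the scatter), so at this place, para to a large group, the read-out does not separate the two groups. The other step, a number 25 percentage points lower from compound 1 to compound 3 (beyond the scatter), shows that the difference from the 2-chlorophenyl member seen with compound 2 recurs with a second group at that place. Nothing measured here accounts for this result.

Compound 1 differs from compounds 2 and 3 in both the group and its place on the ring, so these compounds leave open which of the two matters; a 4-chlorophenyl member would separate them. Also open, on these data alone, is whether a group of another kind at the same place, such as an amine or a carboxylic acid, would leave the read-out as it stands.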